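The compounds below may be only part of what the source reports. "The series", "measured", "known", "first", "only" and "open" are said of these compounds alone.

Compound 1 `NS(=O)(=O)c1ccc(/C=C/c2ccc(F)cc2)cc1`: 29400 nM
Compound 2 `NS(=O)(=O)c1ccc(/C=C/c2ccc(O)cc2)cc1`: 17800 nM
Compound 3 `CN(C)c1ccc(/C=C/c2ccc(S(N)(=O)=O)cc2)cc1`: not yet measured

In a functional assay on HT-29 cells (Homo sapiens) for inhibition (a higher number here means a weaker inhibitor of growth, a lower number a stronger inhibitor of growth), compound 2 gives 17800 nM, which lies within the scatter of compound 1, so the two cannot be ranked. The next step leads to compound 3, with dimethylamino in place of hydroxy on an aromatic carbon; in words, dimethylamino in place of hydroxy on an aromatic carbon. Going by the values given here, only one measured step bears on this: a 1.7-fold lower number from compound 1 to compound 2 (0.22 log units; within the scatter), also an exchange of the group on an aromatic carbon. Among the compounds with values here, no measured compound carries dimethylamino, so the evidence is thin and no direction can be drawn from it. No shift beyond the scatter is expected in this assay, though the range is kept wide. The expected change is a 1.3-fold lower number from compound 2 to compound 3 (0.10 log units; within the scatter). For compound 3 the estimated value is 14000 nM, with an expected range of 4000 nM to 40000 nM.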

Compound 3, concentration for 50% growth inhibition: 30800 nM
For compound 3 the middle estimate is 2.2-fold (0.34 log units) below the measured one; the measured number falls inside the stated range.
By their numbers in this assay, from the lowest: compounds 2, 1 and 3 (each within the scatter of the next).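

In this assay, dimethylamino in place of hydroxy gives a 1.7-fold higher number from compound 2 to compound 3 (0.24 log units; within the scatter), and dimethylamino in place of fluoro gives a 1.0-fold higher number from compound 1 to compound 3 (0.02 log units; within the scatter), so the three groups on this aromatic carbon, para to a large group, cannot be ranked. Going by these compounds alone, the earlier pair covered only two small groups; here, a group of 3 heavy atoms with 0 hydrogen-bond donors also produces no step beyond the scatter. Nothing available accounts for this flat reading.

On these data alone, whether a carboxylic acid, a primary amine or a longer alkyl chain on this carbon would produce a step beyond the scatter remains open. Also open, as far as these compounds go, is whether changes elsewhere on the shared core would move the number at all.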